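Branched chain shortened on the double-bonded nitrogen

The source may report more compounds than this note shows. Statements on the series, on what has been measured and on what is new or still open speak of the compounds shown alone.

Compound 1 `CCCCCC/N=C(\C)c1c(O)c2ccccc2oc1=O` gives 2900 nM in an assay on isolated protein for inhibition of myosin-2 (Bos taurus), read by spectrophotometry, with a stated time of 24 min; on this read-out higher numbers stand for weaker inhibition and lower numbers for stronger inhibition. Compound 2 `CCC(C)/N=C(\C)c1c(O)c2ccccc2oc1=O` reports only a limit in this assay, >= 100000 nM, one of the values sitting at the limit of >= 100000 nM in this assay, at which 1 of the 2 values shown sits. Among the compounds with values here, the single measured step, an at least 34-fold higher number from compound 1 to compound 2 (1.53 log units; beyond the scatter), is large and points to weaker inhibition as the chain shortens and branches. Compound 3 `C/C(=N\C(C)C)c1c(O)c2ccccc2oc1=O` differs from compound 2 by hydrogen in place of methyl on a saturated chain carbon, two bonds along the chain from a double-bonded nitrogen, trimming the branched chain further. With compound 2 already at the limit, the expected step that the limit leaves unreadable from compound 2 to compound 3 is none beyond the scatter, most likely another limit. Compound 3 is estimated at 150000 nM, within 30000 nM to 600000 nM.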

Compound 3, half-maximal inhibitory concentration: >= 100000 nM
Compound 3 gave a limit, no number; the forecaster's own chance of this, stated with the estimate: 80%; the middle value lies beyond the limit too.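

Compound 3, with isopropyl on the double-bonded nitrogen, also gives only a limit, so trimming the methyl from the sec-butyl chain does not restore a readable value. Hexyl to isopropyl gives an at least 34-fold higher number from compound 1 to compound 3 (1.53 log units; beyond the scatter), so two short branched chains now stand against the hexyl of compound 1. The step from compound 2 to compound 3 cannot be read, and the two compounds cannot be ranked: the limit of >= 100000 nM in this assay, at which 2 of the 3 values shown sit.

The compounds shown do not separate chain length from branching, since they include no short unbranched chain such as butyl. On these data alone, how a chain longer than hexyl, or one ending in an amine, would read remains open.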